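This account rests on a few compounds, and the source may have more. Where it says the series, first, only, none or still open, it means among the compounds named here.

Working notes on the series in an ADME assay on CEM-SS cells (Homo sapiens) for cytotoxicity, read by XTT assay, with a stated time of 6 days; a higher number here means that more compound is tolerated, a lower number that less compound is tolerated. Within the data shown here, compound 1 `CCCC(=O)OCSc1ccccc1C(=O)NCCCCC(N)=O` stands at 51.7 uM, its only number here, with one further entry that gives no single number. Compound 2 `CCCC(=O)OCSc1ccccc1C(=O)N[C@H]1CCC[C@@H]1C(N)=O` reads 31.2 uM; 43.3 uM (2 entries), and its repeats are recorded as the several entries of compound 2 in this assay, 31.2 uM; 43.3 uM (2 entries). These values and that of compound 1 lie within the usual scatter of each other. The step followed here leads to compound 3 `CCCC(=O)OCSc1ccccc1C(=O)N(C)CC(=O)NC`, which carries methyl((methylcarbamoyl)methyl)amino in place of (4-carbamoylbutyl)amino on a carbonyl carbon. Among the measured compounds shown here, no measured step speaks to this change, so no shift beyond the scatter is expected in this assay, in either direction. The expected step, a 1.1-fold lower number from compound 1 to compound 3 (0.06 log units; within the scatter), is accordingly small. For compound 3 the estimate is 45 uM, with an expected range of 20 uM to 100 uM.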

Compound 3, half-maximal toxic concentration: 62.5 uM
The estimate for compound 3 lay 1.4-fold (0.14 log units) below the measured number; the measured number falls inside the stated range.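

In this assay, among these compounds, methyl((methylcarbamoyl)methyl)amino in place of (4-carbamoylbutyl)amino on a carbonyl carbon gives a 1.2-fold higher number from compound 1 to compound 3 (0.08 log units; within the scatter), the first step that can be read at this position. For this one pair, exchanging the open (4-carbamoylbutyl)amino group, with its 2 hydrogen-bond donors, for an entering group with 1 leaves the number within the scatter. The step is no larger than the gap between repeat entries of a single compound: the several entries of compound 2 in this assay, 31.2 uM; 43.3 uM (2 entries)

Still open, as far as these compounds go, is whether an amine or a carboxylic acid at the end of this group, or a longer chain on the same carbonyl carbon, would move the number beyond the scatter. With a single step read, a change elsewhere on the core of compound 1 also remains an open question.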